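Trimming the terminal ether of compound 1

The source may report more compounds than this note shows. Statements on the series, on what has been measured and on what is new or still open speak of the compounds shown alone.

In an assay on brain for displacement of a labelled ligand from Adrenergic receptor alpha-1 (Rattus norvegicus) (a higher number here means a weaker inhibitor, a lower number a stronger inhibitor), compound 1 `CCOCCOC1CCN(c2nc(N)c3cc(OC)c(OC)cc3n2)CC1` gives 1.81 nM, the higher of the two numbers in hand; compound 2 `COc1cc2nc(N3CCC(OCCOc4ccccc4)CC3)nc(N)c2cc1OC` gives 0.48 nM. Within the data shown here, the single measured step, a 3.8-fold lower number from compound 1 to compound 2 (0.58 log units; beyond the scatter), enlarges the ether terminus. Compound 3 `COc1cc2nc(N3CCC(OCCO)CC3)nc(N)c2cc1OC` goes the opposite way: hydrogen in place of ethyl on an oxygen on a saturated carbon, read one bond further out as ethoxy to hydroxy. Among the measured compounds shown here, no measured pair removes the ethyl outright, so the direction is only loosely anchored on that one step. A modest rise in the number is expected for compound 3, a 1.9-fold higher number from compound 1 to compound 3 (0.29 log units; within the scatter). Compound 3 is estimated at 3.5 nM, range 1.2 nM to 10 nM.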

Compound 3, inhibition constant: 2.2 nM
Compound 3: middle estimate off by 1.6-fold (0.20 log units), on the high side; the measured number falls inside the stated range.
By their numbers in this assay, from the lowest: compound 2; then compounds 1 and 3 (each within the scatter of the next).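

In this assay, hydrogen in place of ethyl on this oxygen leaves the number within the scatter (a 1.2-fold higher number from compound 1 to compound 3 (0.08 log units; within the scatter)), so ethoxy and hydroxy are not told apart here. Hydrogen in place of phenyl on the same oxygen gives a step beyond the scatter (a 4.6-fold higher number from compound 2 to compound 3 (0.66 log units; beyond the scatter)), and among these three compounds only the phenyl terminus separates from the others. No evidence in hand bears on the reason for this.

Going by these compounds, how an amine or a carboxylic acid in place of the hydroxy would read remains open. So does whether the phenyl gain would hold on a longer chain.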